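Benzyl substituent variation and microsomal half-life in the series

This account rests on a few compounds, and the source may have more. Where it says the series, first, only, none or still open, it means among the compounds named here.

Measured compounds in an ADME assay on microsomes from liver (Homo sapiens) for metabolic stability, read by LC-MS, using NADPH, tested at 5 uM; on this read-out lower numbers stand for a shorter-lived compound and higher numbers for a longer-lived compound:
compound 1 `Cc1cc(S(=O)(=O)/N=C(\N)n2nccc2-c2ccccc2)c(SCc2ccc(Cl)cc2)cc1Cl`: 0.34 h
compound 2 `Cc1cc(S(=O)(=O)/N=C(\N)n2nccc2-c2ccccc2)c(SCc2ccccc2Cl)cc1Cl`: 0.226 h
compound 3 `Cc1cc(-c2ccccc2)n(/C(N)=N/S(=O)(=O)c2cc(C)c(Cl)cc2SCc2ccccc2C)n1`: 0.154 h

Compound 3 stands lowest of the three numbers in this assay. Its nearest neighbour is compound 2, within the scatter; its furthest is compound 1, beyond the scatter. For the measured compounds named here, the one measured step, a 1.5-fold lower number from compound 1 to compound 2 (0.18 log units; within the scatter), concerns the position of the chlorine on the benzyl group and does not touch the methyl that is changed here.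

Compound 4 `Cc1cc(-c2ccccc2)n(/C(N)=N/S(=O)(=O)c2cc(C)c(Cl)cc2SCc2ccccc2C(F)(F)F)n1` differs from compound 3 by trifluoromethyl in place of methyl on an aromatic carbon, on an aromatic carbon ortho to a large group. Going by the values given here, no measured step covers a methyl to trifluoromethyl exchange, so the expectation rests only on compound 3 and on the narrow spread of the three numbers in this assay.

Compound 4 is expected to give 0.17 h, with a range from 0.08 h to 0.36 h. The step of a 1.1-fold higher number from compound 3 to compound 4 (0.04 log units; within the scatter) is thus expected to stay within the scatter, in no clear direction.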

Compound 4, half-life: 0.306 h
Beside the measured number, compound 4's estimate is 1.8-fold (0.26 log units) below it; low and high end bracket the measured number.
By their numbers in this assay, from the lowest: compounds 3, 2, 4 and 1 (each within the scatter of the next, the first and the last beyond it).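

In this assay, for the compounds shown here, the exchange at this place gives a 2.0-fold higher number from compound 3 to compound 4 (0.30 log units; within the scatter), the first reading for this position, as the one earlier step concerned only where the chlorine sits on the benzyl group. Going from methyl to trifluoromethyl on an aromatic carbon ortho to a large group adds three heavy atoms, all fluorine, yet the step stays within the scatter, so this single pair shows no clear effect of the exchange on half-life. Nothing available bears on the cause of this result.

From the compounds shown here alone, whether a methoxy group, a nitrile or a carboxylic acid at this place would read the same remains open. So does whether trifluoromethyl would give a similar step elsewhere on the benzyl group or with a chlorine in the series.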